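Will a benzyl ester shift the antiproliferative reading?

A few compounds are considered here, and "the series" means these few. Any claim that something is new, unique, unknown or untested is made for them only; others in the source may bear on it.

Measured so far in a functional assay on HeLa cells (Homo sapiens) for antiproliferative activity, read by MTT assay, with a stated time of 48 h; on this read-out higher numbers stand for weaker inhibition and lower numbers for stronger inhibition:
Compound 1 `c1ccc(-c2nn(-c3ccccc3)cc2-c2nc3ccccc3[nH]2)cc1` gives 1550 nM here
Compound 2 `COc1ccc2[nH]c(-c3cn(-c4ccccc4)nc3-c3ccccc3)nc2c1` gives 2870 nM here

Compound 2 has only compound 1 for comparison. That comparison shows a 1.9-fold higher number from compound 1 to compound 2 (0.27 log units; within the scatter) and so the two values cannot be told apart.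

In compound 3 `O=C(OCc1ccccc1)c1ccc2[nH]c(-c3cn(-c4ccccc4)nc3-c3ccccc3)nc2c1` benzyloxycarbonyl stands in place of methoxy on an aromatic carbon of the shared core. Counted out, the change reads benzyloxycarbonyl in place of methoxy on an aromatic carbon and it brings in a ring where the departing methoxy has none.

Within the data shown here, only one measured step bears on this. Methoxy in place of hydrogen on an aromatic carbon gave a 1.9-fold higher number from compound 1 to compound 2 (0.27 log units; within the scatter) and that is the sole evidence at hand. Among the measured compounds shown here, no measured compound carries benzyloxycarbonyl, so this small step says little about the much larger entering group. Starting from compound 2 at 2870 nM no clear shift in either direction is expected in this assay and the uncertainty is wide. The estimated step is a 1.1-fold lower number from compound 2 to compound 3 (0.06 log units; within the scatter) and no move beyond the scatter is expected. For compound 3 the expected value is 2500 nM with a likely range from 800 nM to 8000 nM in this estimate.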

Compound 3, half-maximal inhibitory concentration: 21300 nM
Compound 3: middle estimate off by 8.5-fold (0.93 log units), on the low side; measured number outside the range, above it.
By their numbers in this assay, from the lowest: compounds 1 and 2 (each within the scatter of the next); then compound 3.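

In this assay, this position on the shared core proves sensitive to what it carries: hydrogen and methoxy could not be told apart, but benzyloxycarbonyl in place of methoxy gives a 7.4-fold higher number from compound 2 to compound 3 (0.87 log units; beyond the scatter). The same group in place of hydrogen gives a 14-fold higher number from compound 1 to compound 3 (1.14 log units; beyond the scatter), so inhibition on this read-out is clearly weaker with benzyloxycarbonyl than with either smaller substituent. Nothing available explains why this drop occurs.

Benzyloxycarbonyl differs from methoxy in several ways at once, adding a carbonyl, an aromatic ring and more heavy atoms in a single change, so these three compounds cannot show which of those features goes with the weaker reading. A methyl ester at the same position would keep the carbonyl without the added ring, while a benzyloxy group would keep the ring without the carbonyl, and a carboxylic acid or an amide there would show how other groups built around a carbonyl compare.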